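The source may report more compounds than this note shows. Statements on the series, on what has been measured and on what is new or still open speak of the compounds shown alone.

Measured compounds:
compound 1, `Clc1ccc(-c2cn3nc(Cc4ccccc4)sc3n2)cc1`, gives 2200 nM
compound 2, `O=Cc1c(-c2ccc(Br)cc2)nc2sc(Cc3ccccc3)nn12`, gives 2200 nM

Both results come from a functional assay on cells (Cancer cell lines, Homo sapiens) for inhibition; on this read-out lower numbers stand for stronger inhibition of growth and higher numbers for weaker inhibition of growth. Compound 1 gives 2200 nM in this assay, and compound 2 gives 2200 nM. At the digits shown compound 2 stands level with compound 1, its nearest neighbour, and the two values differ by nothing beyond the usual scatter of such measurements; no single-point comparison between them is available, so only the numbers themselves can be read.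

The next compound, compound 3, `O=Cc1c(-c2ccc([N+](=O)[O-])cc2)nc2sc(Cc3ccccc3)nn12`, differs from compound 2 in one place: nitro in place of bromo on an aromatic carbon. Among the measured compounds shown here, no measured pair shows what such a swap does here, so the account rests on compound 2 alone. The expected step of a 1.1-fold higher number from compound 2 to compound 3 (0.06 log units; within the scatter) is small, with no direction assumed beyond the scatter. Compound 3 is therefore estimated at 2500 nM in this assay, with a range from 700 nM to 9000 nM.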

Compound 3, concentration for 50% growth inhibition: 3100 nM
Compound 3: middle estimate off by 1.2-fold (0.09 log units), on the low side; low and high end bracket the measured number.
By their numbers in this assay, from the lowest: compounds 1, 2 and 3 (each within the scatter of the next).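

On the aromatic carbon para to a large group, nitro in place of bromo gives a 1.4-fold higher number from compound 2 to compound 3 (0.15 log units; within the scatter) in this assay, the only comparison among these compounds that differs in a single place. At this position, 3 heavy atoms and 2 hydrogen-bond acceptors enter where 1 heavy atom leaves, and the number does not move beyond the scatter. No further data bear on this result.

The compounds shown leave open whether an amine or a carboxylic acid on this same aromatic carbon would move the number beyond the scatter. They also leave open what a methoxy group or a longer chain would do there, and whether the swap from bromo to nitro would give a similar step on another core.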